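This account rests on a few compounds, and the source may have more. Where it says the series, first, only, none or still open, it means among the compounds named here.

Measured in an ADME assay on MT4 cells (Homo sapiens) for cytotoxicity; on this read-out lower numbers stand for higher toxicity in this test and higher numbers for lower toxicity in this test:
compound 1 `COC(=O)N[C@H](C(=O)NN(CCC[C@@](O)(Cc1ccccc1)C(=O)N[C@H]1c2ccccc2C[C@H]1O)Cc1ccc(Cl)cc1)C(C)(C)C` — compound 1 gives > 10000 nM, a limit of the assay rather than a number.
compound 2 `COC(=O)N[C@H](C(=O)NN(CCC[C@@](O)(Cc1ccccc1)C(=O)N[C@H]1c2ccccc2C[C@H]1O)CC(C)C)C(C)(C)C` — compound 2 gives > 10000 nM, again a limit.
compound 3 `COC(=O)N[C@H](C(=O)NN(CCC[C@@](O)(Cc1ccccc1)C(=O)N[C@H]1c2ccccc2C[C@H]1O)Cc1ccc(-n2ccnc2)cc1)C(C)(C)C` — compound 3 gives > 10000 nM, again a limit.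

Compound 1 thus stands only at a limit in this assay, and nothing sets it apart from the other two, since all three sit at the same limit (the limit of > 10000 nM in this assay, at which 3 of the 3 values shown sit). Compound 4 `COC(=O)N[C@H](C(=O)NN(CCC[C@@](O)(Cc1ccccc1)C(=O)N[C@H]1c2ccccc2C[C@H]1O)Cc1ccc(-c2ccccc2)cc1)C(C)(C)C` differs from compound 1 by phenyl in place of chloro on an aromatic carbon. The measured steps at this position, a step that the two limits leave unreadable from compound 1 to compound 2, a step that the two limits leave unreadable from compound 1 to compound 3 and a step that the two limits leave unreadable from compound 2 to compound 3, give no readable size because every value sits at the limit (the limit of > 10000 nM in this assay, at which 3 of the 3 values shown sit). Compound 4 is therefore expected to remain at the limit as well, with an expected step that the limit leaves unreadable from compound 1 to compound 4 of no readable size. The estimate for compound 4 is 15000 nM, expected to lie between 5000 nM and 50000 nM.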

Compound 4, half-maximal cytotoxic concentration: 7500 nM
Beside the measured number, compound 4's estimate is 2.0-fold (0.30 log units) above it; low and high end bracket the measured number.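

Among these compounds, in (this assay), compound 4, with its 4-phenylphenyl group, is the only one of the four compounds whose value comes off the limit: (the limit of > 10000 nM in this assay, at which 3 of the 4 values shown sit). This gives the position its first readable steps, (an at least 1.3-fold lower number from compound 1 to compound 4 (0.12 log units; that floor lies within the scatter)), (an at least 1.3-fold lower number from compound 3 to compound 4 (0.12 log units; that floor lies within the scatter)) and (an at least 1.3-fold lower number from compound 2 to compound 4 (0.12 log units; that floor lies within the scatter)). Going by these compounds, each of these is only a floor, so the true size of the change remains unknown, and the steps among compounds 1, 2 and 3 cannot be read. On these data alone, whether an amine or a carboxylic acid on the same aromatic carbon would also leave the limit stays open. So does the effect of a second phenyl ring with a chloro group on it.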